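The source may hold more compounds than are shown below. What is called first, only, known or untested is meant among the compounds shown, and "the series" means these compounds.

Compound 1 `N/C(=N\NC(=S)N1CCCC1)c1ccc(F)cn1` gives 51% in a functional assay on MCF7 cells (Homo sapiens) for cytotoxicity, read by MTT assay, with a stated time of 72 h, tested at 1 uM; on this read-out higher numbers stand for more inhibition of growth at the one concentration tested and lower numbers for less inhibition of growth; compound 2 `N/C(=N\NC(=S)N1CCSCC1)c1ccc(F)cn1` gives 30.6%; compound 3 `N/C(=N\NC(=S)N1CCOCC1)c1ccc(F)cn1` gives 12.4%.

Compound 1 stands highest of the three, with a number 20.4 percentage points lower from compound 1 to compound 2 (beyond the scatter) and a number 38.6 percentage points lower from compound 1 to compound 3 (beyond the scatter), both beyond the scatter; the gap between compound 2 and compound 3 is a number 18.2 percentage points lower from compound 2 to compound 3 (beyond the scatter). Compound 4 `N/C(=N\NC(=S)N1CCCC1)c1ccccn1` differs from compound 1 by hydrogen in place of fluoro on an aromatic carbon. All three measured steps change the group on the thiocarbonyl carbon, so none of them bears on this change at the aromatic ring; the data give no guide for it. Compound 4 is therefore expected to stay close to compound 1, at about 45% within 25% to 62%. This expectation corresponds to a number 6 percentage points lower from compound 1 to compound 4 (within the scatter), not clearly beyond the scatter.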

Compound 4, percent growth inhibition at one concentration: 45.9%
Compound 4: the middle estimate sits 0.9 percentage points below what was measured; the measured number falls inside the stated range.
By their numbers in this assay, from the lowest: compound 3; then compound 2; then compounds 4 and 1 (each within the scatter of the next).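

In this assay, putting hydrogen in place of fluoro on the aromatic carbon para to a large group gives a number 5.1 percentage points lower from compound 1 to compound 4 (within the scatter). With pyrrolidin-1-yl kept on the thiocarbonyl carbon, fluoro at this position is therefore not needed to hold the reading within the scatter, unlike the changes of the group on the thiocarbonyl carbon. Nothing at hand offers an explanation of this result. Open, as far as these compounds go, is whether chloro, methoxy or an amine at this position would behave like hydrogen. Also open, from the compounds shown here alone, is whether the same change would hold with thiomorpholin-4-yl or morpholin-4-yl in place of pyrrolidin-1-yl.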